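From 4-ethoxyphenyl to 3,4-dimethylphenyl on a carbonyl carbon

A few compounds are considered here, and "the series" means these few. Any claim that something is new, unique, unknown or untested is made for them only; others in the source may bear on it.

Of the compounds shown here, three sharing one core have been measured so far. In a functional assay on A549 cells (Homo sapiens) for antiproliferative activity, read by MTT assay, with a stated time of 48 h (on this read-out higher numbers stand for weaker inhibition and lower numbers for stronger inhibition), compound 1 `COc1ccc(/C=C/c2cc(OC)cc(OC)c2/C=C/C(=O)c2cccc(OC)c2)cc1` gives 6.1 ug/mL, compound 2 `CCCCOc1ccc(C(=O)/C=C/c2c(/C=C/c3ccc(OC)cc3)cc(OC)cc2OC)cc1` gives 8.7 ug/mL and compound 3 `CCOc1ccc(C(=O)/C=C/c2c(/C=C/c3ccc(OC)cc3)cc(OC)cc2OC)cc1` gives 7.5 ug/mL. Compound 3 therefore lies within the scatter of both of the others, and the three values cannot be told apart.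

The next compound, compound 4 `COc1ccc(/C=C/c2cc(OC)cc(OC)c2/C=C/C(=O)c2ccc(C)c(C)c2)cc1`, differs from compound 3 in one place: 3,4-dimethylphenyl in place of 4-ethoxyphenyl on a carbonyl carbon. In words, it has 3,4-dimethylphenyl in place of 4-ethoxyphenyl on a carbonyl carbon.

The measured steps that bear on this change were all made at that same place. Putting 4-butoxyphenyl in place of 3-methoxyphenyl gave a 1.4-fold higher number from compound 1 to compound 2 (0.15 log units; within the scatter). Putting 4-ethoxyphenyl in place of 3-methoxyphenyl gave a 1.2-fold higher number from compound 1 to compound 3 (0.09 log units; within the scatter). Moving from the butoxy to the ethoxy group gave a 1.2-fold lower number from compound 2 to compound 3 (0.06 log units; within the scatter).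

Among the measured compounds shown here, none of these steps left the scatter, but no measured compound carries the 3,4-dimethylphenyl group, so the data test it only indirectly. In this assay, no step beyond the scatter is therefore expected. The estimated change is a 1.1-fold lower number from compound 3 to compound 4 (0.03 log units; within the scatter), in no firm direction. For compound 4 the expected value is 7 ug/mL, with an estimated range from 3.5 ug/mL to 14 ug/mL.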

Compound 4, half-maximal inhibitory concentration: 0.1 ug/mL
For compound 4 the middle estimate is 70-fold (1.85 log units) above the measured one; measured number outside the range, below it.
By their numbers in this assay, from the lowest: compound 4; then compounds 1, 3 and 2 (each within the scatter of the next).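

In this assay this place on the carbonyl carbon had looked indifferent among 3-methoxyphenyl, 4-ethoxyphenyl and 4-butoxyphenyl, but 3,4-dimethylphenyl shows that it responds strongly to the group it carries. The new group gives a 75-fold lower number from compound 3 to compound 4 (1.88 log units; beyond the scatter) and an 87-fold lower number from compound 2 to compound 4 (1.94 log units; beyond the scatter) as well as a 61-fold lower number from compound 1 to compound 4 (1.79 log units; beyond the scatter) so its steps from all three earlier compounds lie beyond the scatter, and compound 4 has the lowest number of the four. Compound 4 is also the only one of the four whose group on the carbonyl carbon has no oxygen and no hydrogen-bond acceptor, but nothing measured here explains why the step is so large.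

The change removes an oxygen-linked chain and adds two methyl groups in one step, so the compounds shown leave open whether a single methyl group, as in 4-methylphenyl or 3-methylphenyl, would give a number close to that of compound 4 or whether both methyl groups are needed. They also leave open whether other groups without oxygen, such as unsubstituted phenyl or 4-chlorophenyl, would fall with compound 4 or with the other three compounds.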